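Aryl swap on the amide nitrogen: expected cytotoxicity

The source may hold more compounds than are shown below. What is called first, only, known or untested is meant among the compounds shown, and "the series" means these compounds.

Measured compounds:
compound 1, `COc1ccc2nc(C)cc(OCC(=O)Nc3ccccc3)c2c1`: 118000 nM
compound 2, `COc1ccc(NC(=O)COc2cc(C)nc3ccc(OC)cc23)cc1`: > 142000 nM

Both compounds were tested in an ADME assay on HepG2 cells (Homo sapiens) for cytotoxicity, read by trypan blue exclusion, with a stated time of 48 h, in the presence of a further agent that is not named here; on this read-out higher numbers stand for lower toxicity in this test and lower numbers for higher toxicity in this test. In this assay compound 1 gives 118000 nM. For compound 2 the result is a limit of the assay, not a number, namely > 142000 nM. Within the data shown here, the one measured step, an at least 1.2-fold higher number from compound 1 to compound 2 (0.08 log units; that floor lies within the scatter), therefore rests on a floor, and the limit of > 142000 nM in this assay, at which 1 of the 2 values shown sits, shows that one of the two values sits at that floor. On the numbers shown, compound 2 stands at or beyond the high end.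

Compound 3, `COc1ccc2nc(C)cc(OCC(=O)Nc3cccc(Br)c3)c2c1`, differs from compound 2 by 3-bromophenyl in place of 4-methoxyphenyl on an amide-type nitrogen. Among the measured compounds shown here, the only measured step concerns a methoxy in place of hydrogen on an aromatic carbon, and it lies within the scatter; no measured step concerns bromine. Removing the methoxy is expected to bring compound 3 back toward compound 1, so the step of an at least 1.4-fold lower number from compound 2 to compound 3 (0.15 log units; that floor lies within the scatter) is expected to be small and possibly within the scatter. Compound 3 is estimated at 100000 nM, with a range from 45000 nM to 220000 nM in this assay.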

Compound 3, half-maximal cytotoxic concentration: > 125000 nM
Compound 3: only a limit was reported (the forecaster's own chance of this, stated with the estimate: 30%); middle value at least 1.2-fold (0.09 log units) from the limit.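

In this assay, like compound 2, compound 3 returns a limit of the assay rather than a number: > 125000 nM. This shows that the amide-type nitrogen also carries 3-bromophenyl, a group with bromine rather than oxygen, without any measured number falling below that of compound 1: bromo in place of hydrogen on an aromatic carbon gives an at least 1.0-fold higher number from compound 1 to compound 3 (0.02 log units; that floor lies within the scatter), and that figure is only a floor. With limits now standing for two of the three compounds, the step between compound 2 and compound 3 cannot be read, so neither 3-bromophenyl nor 4-methoxyphenyl can be placed ahead of the other.

The compounds shown leave open how far the true values of compound 2 and compound 3 lie from that of compound 1, since no step shown is established beyond the usual scatter. They also leave open whether this tolerance extends past halogen and methoxy substituents on the phenyl ring, for instance to an amine or a carboxylic acid at the same place.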